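Swapping the hydroxyindanylamine for a benzylaminomethyl arm

The source may hold more compounds than are shown below. What is called first, only, known or untested is meant among the compounds shown, and "the series" means these compounds.

Compound 1 `COC[C@H](NC1CCN(CCCc2c[nH]c3ccc(Cn4cncn4)cc23)CC1)c1ccc(F)cc1`: 5 nM
Compound 2 `O[C@H]1Cc2ccccc2C1NC1CCN(CCCc2c[nH]c3ccc(-n4cnnc4)cc23)CC1`: 37 nM

In an assay on CHO cells for displacement of a labelled ligand from 5-hydroxytryptamine receptor 1D (Homo sapiens) (a lower number here means a stronger inhibitor, a higher number a weaker inhibitor), compound 1 gives 5 nM and compound 2 gives 37 nM, the higher of the two numbers and beyond the scatter from compound 1. Among the measured compounds shown here, compound 3 `c1ccc(CNCC2CCN(CCCc3c[nH]c4ccc(-n5cnnc5)cc34)CC2)cc1` differs from compound 2 in one place: (benzylamino)methyl in place of (2-hydroxy-2,3-dihydro-1H-inden-1-yl)amino on a saturated ring carbon No step between measured compounds shows what such a change does here. The hydroxyl and the extra ring are lost, so a modest move toward a weaker inhibitor is expected, namely a 1.9-fold higher number from compound 2 to compound 3 (0.28 log units; within the scatter). Compound 3 is therefore estimated at 70 nM, in a range from 15 nM to 300 nM.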

Compound 3, half-maximal inhibitory concentration: 1.6 nM
For compound 3 the middle estimate is 44-fold (1.64 log units) above the measured one; the measured number lies below the stated range.
By their numbers in this assay, from the lowest: compound 3; then compound 1; then compound 2.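

In this assay the change on this saturated ring carbon gives a 23-fold lower number from compound 2 to compound 3 (1.36 log units; beyond the scatter) and so shows that this position responds strongly to the group it carries. The hydroxyl and the five-membered ring of carbon only are not needed for a low number in this pair. Nothing measured here explains the gain.

The change alters several features at once, so the compounds shown do not separate their contributions. On these data alone, whether a plain aminomethyl group would keep the low number also remains open.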